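A few compounds are considered here, and "the series" means these few. Any claim that something is new, unique, unknown or untested is made for them only; others in the source may bear on it.

Measured so far:
- compound 1 `CCN1C(=O)CS/C1=N/Nc1nncc2ccccc12` gives 0.9 nM
- compound 2 `C(=C/c1ccccc1)\C(=N\Nc1nncc2ccccc12)c1ccccc1` gives 0.01 nM
- compound 3 `O=S(=O)(Nc1ncccn1)c1ccc(Nc2nncc3ccccc23)cc1` gives 0.8 nM

All three values come from a functional assay on SK-OV-3 cells (Homo sapiens) for antiproliferative activity, read by sulforhodamine B assay, with a stated time of 72 h (a lower number here means a stronger inhibitor, a higher number a weaker inhibitor), and compound 2 has the lowest number of the three. Its gaps to compound 3 and to compound 1 both lie beyond the scatter, while compound 1 and compound 3 sit within the scatter of each other. Within the data shown here, these compounds differ in more than one place, so no measured step isolates a single change.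

Compound 4 `Clc1ccc(C(/C=C/c2ccccc2)=N\Nc2nncc3ccccc23)cc1` differs from compound 2 by chloro in place of hydrogen on an aromatic carbon (chloro in place of hydrogen on an aromatic carbon, para to a large group, turning phenyl into 4-chlorophenyl). Among the measured compounds shown here, no measured pair shows the effect of such a change, so the expectation is loosely founded. With compound 2 at 0.01 nM at the low extreme of the set, a modest move to a higher number in this assay is expected. The estimated move is a 3.0-fold higher number from compound 2 to compound 4 (0.48 log units; beyond the scatter) and it is expected to stay small against the gaps above. For compound 4 the estimated value is 0.03 nM with an expected range from 0.005 nM to 0.3 nM in this read-out.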

Compound 4, half-maximal inhibitory concentration: 0.07 nM
Compound 4: the middle estimate sits 2.3-fold (0.37 log units) below what was measured; low and high end bracket the measured number.
By their numbers in this assay, from the lowest: compound 2; then compound 4; then compounds 3 and 1 (each within the scatter of the next).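

In this assay the series now has its first step that isolates one change: chloro in place of hydrogen on an aromatic carbon, para to a large group, gives a 7.0-fold higher number from compound 2 to compound 4 (0.85 log units; beyond the scatter) and so costs activity. The step is modest but beyond the scatter, so hydrogen and chloro are distinguishable at this position, and compound 4 still gives 0.07 nM with the 4-chlorophenyl group in place. Nothing available bears on why the number rises with this change.

From the compounds shown here alone, whether fluoro, a methoxy group or an amine in the same place would move the number in the same way remains open. So does the effect of chloro on the other phenyl of compound 2, and a single step sets no trend across substituents.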